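Thiazolidinone anilines: cytotoxicity on colon cells, next analogue

The source may hold more compounds than are shown below. What is called first, only, known or untested is meant among the compounds shown, and "the series" means these compounds.

Measured so far:
compound 1 `COc1ccc(-c2cc(/N=C3/NC(=O)CS3)cs2)cc1` — in a functional assay on SW-620 cells (Homo sapiens) for cytotoxicity, read by MTT assay, with a stated time of 72 h (on this read-out higher numbers stand for weaker inhibition and lower numbers for stronger inhibition), compound 1 gives > 50000 nM, a limit of the assay.
compound 2 `O=C1N/C(=N/c2csc(-c3ccc(Cl)cc3)c2)S/C1=C\c1ccccc1` — in this assay compound 2 gives > 50000 nM, again a limit.
compound 3 `CN(C)c1ccc(/C=C2\S/C(=N\c3csc(-c4ccc(Cl)cc4)c3)NC2=O)cc1` — in this assay compound 3 gives 800 nM.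

Going by the values given here, compound 3 therefore holds the only actual number in this assay; the other two sit at the limit described by the limit of > 50000 nM in this assay, at which 2 of the 3 values shown sit. Among the compounds with values here, the one measured step, an at least 62-fold lower number from compound 2 to compound 3 (1.79 log units; beyond the scatter), is large and beyond the scatter. Compound 4 `O=C1N/C(=N/c2csc(-c3ccc(Cl)cc3)c2)S/C1=C\c1ccccn1` differs from compound 3 by pyridin-2-yl in place of 4-(dimethylamino)phenyl on a double-bonded chain carbon bound to a double-bonded ring carbon. This change removes the group whose arrival produced that large step, so a rise in this assay back toward the limit is expected, with a fair chance that compound 4 itself reports only a limit. Compound 4 is estimated at 25000 nM (range 4000 nM to 60000 nM), an expected step of a 31-fold higher number from compound 3 to compound 4 (1.49 log units; beyond the scatter).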

Compound 4, half-maximal inhibitory concentration: > 50000 nM
Compound 4: only a limit was reported (the forecaster's own chance of this, stated with the estimate: 50%); middle value at least 2.0-fold (0.30 log units) from the limit.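

In this assay, pyridin-2-yl in place of 4-(dimethylamino)phenyl on this double-bonded chain carbon gives an at least 62-fold higher number from compound 3 to compound 4 (1.79 log units; beyond the scatter), so an aromatic ring with a nitrogen in it does not restore what the 4-(dimethylamino)phenyl group gives here. Of the groups shown at this position, only 4-(dimethylamino)phenyl yields an actual number: the limit of > 50000 nM in this assay, at which 3 of the 4 values shown sit. The step between compound 2 and compound 4 cannot be read, since both values are limits.

On these data alone, it remains open whether 4-aminophenyl or 4-(diethylamino)phenyl at this position would also give a number under the limit. As far as these compounds go, the order of phenyl and pyridin-2-yl also remains unknown.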